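Hydrazone aryl swaps in a cytotoxicity series: compound 4

The compounds below may be only part of what the source reports. "The series", "measured", "known", "first", "only" and "open" are said of these compounds alone.

Measured so far:
- compound 1, `COc1ccccc1-c1nnc(-c2ccc(C(=O)N/N=C/c3cc(O)ccc3O)cc2)o1`: 100000 nM
- compound 2, `COc1ccccc1-c1nnc(-c2ccc(C(=O)N/N=C/c3cccc(F)c3)cc2)o1`: 353000 nM
- compound 3, `COc1ccccc1-c1nnc(-c2ccc(C(=O)N/N=C/c3ccccc3[N+](=O)[O-])cc2)o1`: 161000 nM

In an ADME assay on THP-1 cells (Homo sapiens) for cytotoxicity (on this read-out higher numbers stand for weaker inhibition and lower numbers for stronger inhibition), compound 3 sits between the other two: its number and that of compound 1 lie within the scatter of each other (a 1.6-fold higher number from compound 1 to compound 3 (0.21 log units; within the scatter)), while compound 2 is set apart by a 2.2-fold lower number from compound 2 to compound 3 (0.34 log units; beyond the scatter). Compound 4, `COc1ccccc1-c1nnc(-c2ccc(C(=O)N/N=C/c3ccncc3)cc2)o1`, carries pyridin-4-yl in place of 2-nitrophenyl on a carbon with a double bond to nitrogen. For the measured compounds named here, no pyridine has been measured here, so the only guide is the spread of the three aryl swaps at this same carbon: a 3.5-fold higher number from compound 1 to compound 2 (0.55 log units; beyond the scatter), a 1.6-fold higher number from compound 1 to compound 3 (0.21 log units; within the scatter) and a 2.2-fold lower number from compound 2 to compound 3 (0.34 log units; beyond the scatter), all small or modest. A step of similar size, in either direction, is therefore expected in this assay, most likely a 1.2-fold higher number from compound 3 to compound 4 (0.09 log units; within the scatter). Compound 4 is estimated at 200000 nM, in the range 80000 nM to 500000 nM.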

Compound 4, half-maximal inhibitory concentration: 173000 nM
Estimate against measurement, compound 4: 1.2-fold (0.06 log units) above; the measured number falls inside the stated range.
By their numbers in this assay, from the lowest: compounds 1, 3 and 4 (each within the scatter of the next); then compound 2.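

Pyridin-4-yl, the first aromatic ring with a hetero atom on this carbon, shows no separation from 2-nitrophenyl in this assay, with a 1.1-fold higher number from compound 3 to compound 4 (0.03 log units; within the scatter) on that swap, and none from 2,5-dihydroxyphenyl, with a 1.7-fold higher number from compound 1 to compound 4 (0.24 log units; within the scatter) on that one. Among the four aryl groups, only 3-fluorophenyl stands apart, with a 2.0-fold lower number from compound 2 to compound 4 (0.31 log units; beyond the scatter) marking its separation from pyridin-4-yl. Nothing available explains this grouping. Still open, as far as these compounds go, is whether an aminophenyl or a carboxyphenyl on this carbon would stay with compound 1, compound 3 and compound 4 or move away from them.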